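The source may hold more compounds than are shown below. What is called first, only, known or untested is meant among the compounds shown, and "the series" means these compounds.

Measured in an ADME assay on MT4 cells (Homo sapiens) for cytotoxicity, read by MTT assay; a higher number here means that more compound is tolerated, a lower number that less compound is tolerated:
- compound 1 `Cc1cccc(C(=O)N(C(=S)OCCN2C(=O)c3ccccc3C2=O)c2ccc(Cl)cc2)c1`: 58000 nM
- compound 2 `O=C1c2ccccc2C(=O)N1CCOC(=S)N(C(=O)c1cccc(F)c1F)c1ccc(Cl)cc1`: 58000 nM

Compound 2, at 58000 nM, stands level with compound 1 in this assay. Compound 3 `O=C1c2ccccc2C(=O)N1CCOC(=S)N(C(=O)c1cc(F)cc(F)c1)c1ccc(Cl)cc1` carries 3,5-difluorophenyl in place of 2,3-difluorophenyl on a carbonyl carbon. Within the data shown here, one measured step bears on this, the change on that same carbonyl carbon, no change at the digits printed from compound 1 to compound 2 (within the scatter), which stayed within the scatter. That is a single step, so the support is thin, and no step beyond the scatter is expected here. The estimated step is no change at the digits printed from compound 2 to compound 3 (within the scatter). The expected value for compound 3 is 58000 nM, with an estimated range of 28000 nM to 110000 nM.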

Compound 3, half-maximal cytotoxic concentration: 59000 nM
Compound 3: middle estimate off by 1.0-fold (0.01 log units), on the low side, and the stated range covers the measured number.
By their numbers in this assay, from the lowest: compounds 1, 2 and 3 (each within the scatter of the next).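

On the carbonyl carbon whose other neighbour is the amide-type nitrogen, 3,5-difluorophenyl in place of 2,3-difluorophenyl gives a 1.0-fold higher number from compound 2 to compound 3 (0.01 log units; within the scatter) in this assay, so this rearrangement of the two fluorines leaves the reading flat. 3,5-Difluorophenyl in place of 3-methylphenyl gives a 1.0-fold higher number from compound 1 to compound 3 (0.01 log units; within the scatter), so all three aryl groups now read alike at this carbonyl carbon. Nothing available explains this flat reading. As far as these compounds go, whether it would hold with an amine or a carboxylic acid on this aryl ring, or with a cyclohexyl group in its place, remains open.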